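Swapping the Amide Aryl Group: Methoxy for Dimethyl

A few compounds are considered here, and "the series" means these few. Any claim that something is new, unique, unknown or untested is made for them only; others in the source may bear on it.

Compound 3 `COc1ccc2c(=O)c(/C=C/C(=O)Nc3cc(C)ccc3C)coc2c1` gives the lowest of the two numbers in a functional assay on A549 cells (Homo sapiens) for inhibition, read by MTT assay, with a stated time of 48 h (on this read-out higher numbers stand for weaker inhibition and lower numbers for stronger inhibition), at 15500 nM; its nearest neighbour, compound 2 `COc1ccc2c(=O)c(/C=C/C(=O)Nc3ccccc3)coc2c1`, gives 51000 nM. Compound 1 `COc1ccc2c(=O)c(/C=C/C(=O)Nc3cccc(C)c3)coc2c1` reaches only the limit > 100000 nM, so no number is known for it (the limit of > 100000 nM in this assay, at which 1 of the 3 values shown sits). Compound 4 `COc1cccc(NC(=O)/C=C/c2coc3cc(OC)ccc3c2=O)c1` differs from compound 3 in one place: 3-methoxyphenyl in place of 2,5-dimethylphenyl on an amide-type nitrogen. Going by the values given here, two measured steps bear on this. Putting 2,5-dimethylphenyl in place of phenyl gave a 3.3-fold lower number from compound 2 to compound 3 (0.52 log units; beyond the scatter), while removing a methyl from an aromatic carbon gave an at least 1.9-fold lower number from compound 1 to compound 2 (0.29 log units; that floor lies within the scatter). Since compound 4 carries a single group on its phenyl ring, as compound 1 does, weaker inhibition than compound 3 is expected, roughly a 3.9-fold higher number from compound 3 to compound 4 (0.59 log units; beyond the scatter). Compound 4 is therefore estimated at 60000 nM, likely between 20000 nM and 200000 nM.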

Compound 4, half-maximal inhibitory concentration: 12800 nM
Compound 4: middle estimate off by 4.7-fold (0.67 log units), on the high side, outside the stated range (below it).
By their numbers in this assay, from the lowest: compounds 4 and 3 (each within the scatter of the next); then compound 2. At a limit, above all of these: compound 1.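

Replacing 2,5-dimethylphenyl with 3-methoxyphenyl gives a 1.2-fold lower number from compound 3 to compound 4 (0.08 log units; within the scatter), so the two groups cannot be told apart here, while methoxy in place of hydrogen gives a 4.0-fold lower number from compound 2 to compound 4 (0.60 log units; beyond the scatter). Methoxy in place of methyl gives an at least 7.8-fold lower number from compound 1 to compound 4 (0.89 log units; beyond the scatter). That step is only a floor, since compound 1 stands at a limit: the limit of > 100000 nM in this assay, at which 1 of the 4 values shown sits.

Still open, going by these compounds, is how a hydroxy group, an amine or a carboxylic acid on the phenyl ring would compare. Also open, on these data alone, is whether a longer chain, such as ethoxy, in place of the methoxy would keep this level.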